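Furan to Thiophene: Expected Cytotoxicity of Compound 3

The source may report more compounds than this note shows. Statements on the series, on what has been measured and on what is new or still open speak of the compounds shown alone.

Compound 1 `C[C@H]1[C@H](NCc2ccoc2)C[C@H]2C[C@@H]1C2(C)C` has been examined in an ADME assay on MDCK cells (Canis lupus familiaris) for cytotoxicity, read by microscopy, with a stated time of 48 h; on this read-out higher numbers stand for lower toxicity in this test and lower numbers for higher toxicity in this test. In this assay compound 1 gives > 100000 nM, which is a limit of the assay rather than a number. Compound 1 therefore stands at the limit of > 100000 nM in this assay, at which 1 of the 2 values shown sits, so its position is bounded from one side only. Compound 2 `CCOc1ccsc1CN[C@@H]1C[C@H]2C[C@@H]([C@H]1C)C2(C)C` in this assay gives 50000 nM, a measured number. Compound 3 `Cc1ccc(CN[C@@H]2C[C@H]3C[C@@H]([C@H]2C)C3(C)C)s1` has not yet been measured in this assay. It differs from compound 1 by 5-methylthiophen-2-yl in place of furan-3-yl on a saturated chain carbon bound to an amine nitrogen. Among the compounds with values here, no measured pair shows what this change does, so any expectation rests on the two values at hand. Because compound 2 gives 50000 nM in this assay, compound 3 is expected to come out in the same general region. The expected step of an at least 1.4-fold lower number from compound 1 to compound 3 (0.15 log units; that floor lies within the scatter) is small, leaning toward somewhat higher toxicity, and may well lie within the usual scatter. Compound 3 is thus estimated at 70000 nM, with a range from 30000 nM to 150000 nM.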

Compound 3, minimum cytotoxic concentration: 780 nM
For compound 3 the middle estimate is 90-fold (1.95 log units) above the measured one; measured number outside the range, below it.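

Within the data shown here, replacing furan-3-yl with 5-methylthiophen-2-yl on a saturated chain carbon bound to an amine nitrogen gives an at least 120-fold lower number from compound 1 to compound 3 (2.10 log units; beyond the scatter) in this assay, so the group at this place can strongly shift the read-out, which the earlier compounds could not show. This step has a size bounded from one side only, and the full step may be larger, because the value for compound 1 is a limit of the assay: the limit of > 100000 nM in this assay, at which 1 of the 3 values shown sits.

The compounds shown leave open whether the step belongs to the ring sulfur, the methyl group or the point of attachment on the ring, since all three differ together. Unsubstituted thiophen-2-yl and 5-methylfuran-2-yl at this place would help separate these contributions.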